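Dimethylamino tail on the propylamino chain of compound 1

The source may hold more compounds than are shown below. What is called first, only, known or untested is meant among the compounds shown, and "the series" means these compounds.

Measured so far:
compound 1, `CCCNc1nc(NCc2ccc(NC(=O)c3ccc(F)cc3)cc2)c2ccccc2n1`, 1700 nM
compound 2, `CNc1nc(NCc2ccc(C(=O)Nc3ccc(F)cc3)cc2)c2ccccc2n1`, 2900 nM

In a functional assay on HCT-116 cells (Homo sapiens) for inhibition, read by luminescence and resazurin assay, with a stated time of 3 days (a higher number here means a weaker inhibitor, a lower number a stronger inhibitor), compound 1 gives 1700 nM and compound 2 gives 2900 nM. Compound 1 is the one nearer the small end of this pair, but the gap to compound 2 is within the scatter, so the two cannot be told apart on these numbers. For the measured compounds named here, no single-point step between measured compounds is available, and compound 2 differs from compound 1 in more than one place, so it gives no guide to the change considered here.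

Compound 3, `CN(C)CCCNc1nc(NCc2ccc(NC(=O)c3ccc(F)cc3)cc2)c2ccccc2n1`, differs from compound 1 by dimethylamino in place of hydrogen on a saturated chain carbon, three bonds along the chain from a nitrogen on an aromatic ring; it carries the propyl chain of compound 1 extended to 3-(dimethylamino)propyl while the rest of the molecule is kept. With no measured step of this kind in the series, the working expectation for this assay is a step of no clear direction, within or only slightly beyond the scatter, and the estimated step is a 1.1-fold lower number from compound 1 to compound 3 (0.05 log units; within the scatter). Compound 3 is therefore expected to give about 1500 nM in this assay, in the range 500 nM to 5000 nM.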

Compound 3, half-maximal inhibitory concentration: 10000 nM
Estimate against measurement, compound 3: 6.7-fold (0.82 log units) below; the whole stated range lies below it.
By their numbers in this assay, from the lowest: compounds 1 and 2 (each within the scatter of the next); then compound 3.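

In this assay this position does not tolerate every addition: dimethylamino in place of hydrogen on a saturated chain carbon, three bonds along the chain from a nitrogen on an aromatic ring, gives a 5.9-fold higher number from compound 1 to compound 3 (0.77 log units; beyond the scatter) and so moves the series toward weaker inhibition. For the compounds shown here, this is the first step that changes one place only, so it is the first reading of this chain on its own, and between these two chain ends the plain propyl of compound 1 gives the lower number. No measurement on these compounds bears on why the step has this direction or size.

This single step does not separate the dimethylamino group itself from the added chain length, and a butyl or pentyl chain or a 3-methoxypropyl chain would test whether the higher number follows the amine or the extension. Also open, on these data alone, is whether the step depends on the distance along the chain, as a 2-(dimethylamino)ethyl chain or a longer 4-(dimethylamino)butyl chain on the core of compound 1 would show.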